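This account rests on a few compounds, and the source may have more. Where it says the series, first, only, none or still open, it means among the compounds named here.

Working notes on the series. Three compounds share one core and differ only in the aryl group on an aromatic nitrogen of a five-membered aromatic ring with 3 nitrogen: compound 1 `N#CC1=C(N)Oc2c(N)cc3nc4ccccc4nc3c2C12C(=O)N(Cc1cnnn1-c1ccc(Cl)cc1)c1ccccc12`, compound 2 `COc1ccccc1-n1nncc1CN1C(=O)C2(C(C#N)=C(N)Oc3c(N)cc4nc5ccccc5nc4c32)c2ccccc21` and compound 3 `N#CC1=C(N)Oc2c(N)cc3nc4ccccc4nc3c2C12C(=O)N(Cc1cnnn1-c1ccc(Cl)cc1[N+](=O)[O-])c1ccccc12`. In a functional assay on HCT-116 cells (Homo sapiens) for antiproliferative activity, read by MTT assay, with a stated time of 48 h (a higher number here means a weaker inhibitor, a lower number a stronger inhibitor), compound 1 gives > 50000 nM, which is a limit of the assay and not a number. Compound 2 likewise returns only a limit, > 50000 nM. Within the data shown here, compound 3 gives 28700 nM, the single real number in the set, the other two values sitting at the limit of > 50000 nM in this assay, at which 2 of the 3 values shown sit. The step that the two limits leave unreadable from compound 1 to compound 2 is unreadable between the two limits. The steps of an at least 1.7-fold lower number from compound 1 to compound 3 (0.24 log units; that floor lies within the scatter) and an at least 1.7-fold lower number from compound 2 to compound 3 (0.24 log units; that floor lies within the scatter) are known only as floors, and those floors lie within the scatter, so compound 3 cannot be called stronger than the others.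

Compound 4 `N#CC1=C(N)Oc2c(N)cc3nc4ccccc4nc3c2C12C(=O)N(Cc1cnnn1-c1c(Cl)cc(Cl)cc1Cl)c1ccccc12` carries the change (2,4,6-trichlorophenyl in place of 4-chloro-2-nitrophenyl on an aromatic nitrogen). The nitro that set compound 3 apart from compound 1 is gone, and a ring with three chlorines and no acceptors takes its place. Among the measured compounds shown here, no measured compound carries a trichlorophenyl, so no step covers the change directly; the nearest guide is the reverse of an at least 1.7-fold lower number from compound 1 to compound 3 (0.24 log units; that floor lies within the scatter). Compound 4 is therefore expected to lie near 40000 nM, with a range of 12000 nM to 150000 nM and a real chance of only a limit. The expected step is a 1.4-fold higher number from compound 3 to compound 4 (0.14 log units; within the scatter).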

Compound 4, half-maximal inhibitory concentration: 12100 nM
The estimate for compound 4 lay 3.3-fold (0.52 log units) above the measured number; measured number inside the range.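

Among these compounds, at this position, on an aromatic nitrogen of a five-membered aromatic ring with 3 nitrogen, the earlier compounds gave no step that could be read beyond the scatter, whereas in this assay the change to 2,4,6-trichlorophenyl gives a 2.4-fold lower number from compound 3 to compound 4 (0.38 log units; beyond the scatter), which lies beyond it. The floors are also beyond the scatter, with an at least 4.1-fold lower number from compound 2 to compound 4 (0.61 log units; beyond the scatter) and an at least 4.1-fold lower number from compound 1 to compound 4 (0.61 log units; beyond the scatter), so compound 4 can be called the strongest of the four in this assay. The aryl group at this position can therefore move the number beyond the scatter, and a nitro group is not required for a measured number, as compound 4 carries none.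

On these data alone, how far compound 4 truly stands from compound 1 and compound 2 stays open, these two steps being known only as floors: the limit of > 50000 nM in this assay, at which 2 of the 4 values shown sit. Also open is how much of the step from compound 3 comes from losing the nitro group and how much from the added chlorines, and whether a 2,6-dichlorophenyl, or a phenyl ring bearing an amine or a carboxylic acid, would hold the same number.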